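The source may hold more compounds than are shown below. What is called first, only, known or untested is meant among the compounds shown, and "the series" means these compounds.

Compound 1, `COc1ccc(NC(=O)c2c(O)c3cccnc3n(-c3ccccc3)c2=O)cc1`, gives a low number for inhibition of paw swelling in a functional assay on the whole organism for inhibition, with Rattus norvegicus as the target, read by paw edema, at a dose of 100 mg/kg by the oral route (on this read-out higher numbers stand for more inhibition at the one dose given (going by the name of the read-out) and lower numbers for less inhibition), where compound 1 gives 0.3%, the lowest of the three numbers measured. Compound 2, `O=C(Nc1cccc([N+](=O)[O-])c1)c1c(O)c2cccnc2n(-c2ccccc2)c1=O`, gives 5.7%, and compound 3, `O=C(Nc1cnccn1)c1c(O)c2cccnc2n(-c2ccccc2)c1=O`, gives 29.6%. The step of a number 5.4 percentage points higher from compound 1 to compound 2 (within the scatter) stays within the scatter, whereas a number 29.3 percentage points higher from compound 1 to compound 3 (beyond the scatter) and a number 23.9 percentage points higher from compound 2 to compound 3 (beyond the scatter) go beyond it. Compound 4, `O=C(NCc1ccncc1)c1c(O)c2cccnc2n(-c2ccccc2)c1=O`, differs from compound 1 by (pyridin-4-yl)methyl in place of 4-methoxyphenyl on an amide-type nitrogen. Among the measured compounds shown here, the step of a number 29.3 percentage points higher from compound 1 to compound 3 (beyond the scatter), pyrazin-2-yl in place of 4-methoxyphenyl, is the only one bearing on this change, yet no measured compound carries a ring joined through a methyl group, so the guide is loose. A rise of a number 14.7 percentage points higher from compound 1 to compound 4 (beyond the scatter) is therefore expected. Compound 4 is estimated at 15%, between 0% and 35%.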

Compound 4, a percentage reported as inhibition, in the whole organism at one dose (the size of the read-out at that dose, not a potency): 10%
Beside the measured number, compound 4's estimate is 5 percentage points above it; low and high end bracket the measured number.
By their numbers in this assay, from the lowest: compounds 1, 2 and 4 (each within the scatter of the next); then compound 3.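

At the amide-type nitrogen, (pyridin-4-yl)methyl brings no clear change in this assay from the two substituted phenyl groups: the step is a number 9.7 percentage points higher from compound 1 to compound 4 (within the scatter) and a number 4.3 percentage points higher from compound 2 to compound 4 (within the scatter). It does not match pyrazin-2-yl, with a number 19.6 percentage points lower from compound 3 to compound 4 (beyond the scatter), so a nitrogen in the ring does not by itself give the higher number of compound 3. No measured finding here offers an explanation for this difference. The new group differs from pyrazin-2-yl in both its ring and its methyl link, and these two changes cannot be told apart. A pyridin-4-yl ring joined directly to the amide nitrogen, or a benzyl group, would separate them.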